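Trading a ring for carbamoyl on a long-lived compound

The source may hold more compounds than are shown below. What is called first, only, known or untested is meant among the compounds shown, and "the series" means these compounds.

In an ADME assay on microsomes from liver (Homo sapiens) for metabolic stability (on this read-out lower numbers stand for a shorter-lived compound and higher numbers for a longer-lived compound), compound 3 `CC(C)C(Cc1noc(=O)[nH]1)c1ccc(-c2ccc3cccc(F)c3c2)[nH]c1=O` gives > 3 h, which is a limit and not a number, and it stands at the limit of > 3 h in this assay, at which 1 of the 3 values shown sits. Compound 1 `CC(C)C(Nc1nccs1)c1ccc(-c2ccc3cccc(F)c3c2)[nH]c1=O` gives 0.17 h and compound 2 `CC(C)C(c1cnc(N)s1)c1ccc(-c2ccc3cccc(F)c3c2)[nH]c1=O` gives 0.178 h. These two show a 1.0-fold higher number from compound 1 to compound 2 (0.02 log units; within the scatter). Compound 4 `CC(C)C(CC(N)=O)c1ccc(-c2ccc3cccc(F)c3c2)[nH]c1=O` carries carbamoyl instead of the five-membered aromatic ring: a group of 3 heavy atoms (1 carbon, 1 nitrogen, 1 oxygen; no ring) in place of a group of 6 heavy atoms (2 carbon, 2 nitrogen, 2 oxygen; one five-membered aromatic ring with 3 hetero atoms), on a saturated chain carbon, two bonds along the chain from an aromatic carbon. Two large steps bear on this, an at least 17-fold higher number from compound 1 to compound 3 (1.24 log units; beyond the scatter) and an at least 16-fold higher number from compound 2 to compound 3 (1.22 log units; beyond the scatter), and both lead into the ring that now leaves, so part of that gain is expected to be lost in this assay. The expected change is an at least 2.5-fold lower number from compound 3 to compound 4 (0.39 log units; beyond the scatter), towards a shorter life. For compound 4 the estimate is 1.2 h, with an expected range from 0.3 h to 4 h.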

Compound 4, half-life: < 0.0667 h
Compound 4: a limit, no number; the forecaster's own chance of this, stated with the estimate: 25%; middle value at least 17-fold (1.25 log units) from the limit.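

In this assay, replacing the ring of compound 3 with carbamoyl, on a saturated chain carbon, two bonds along the chain from an aromatic carbon, does not keep the long life: the change gives an at least 44-fold lower number from compound 3 to compound 4 (1.65 log units; beyond the scatter). Carbamoylmethyl also does not match either thiazole-containing group, with an at least 2.6-fold lower number from compound 2 to compound 4 (0.42 log units; beyond the scatter) and an at least 2.5-fold lower number from compound 1 to compound 4 (0.40 log units; beyond the scatter), although the shared core stays the same. Compound 4 gives only a limit, not a number: the limit of < 0.0667 h in this assay, at which 1 of the 4 values shown sits.

From the compounds shown here alone, compound 3 is also a limit, which leaves the true size of the drop open: the limit of > 3 h in this assay, at which 1 of the 4 values shown sits. Also open is whether a carboxylic acid or a longer chain ending in carbamoyl in this place would restore the life seen in this assay.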